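Methoxycarbonyl to carboxy on the core of compound 1

This account rests on a few compounds, and the source may have more. Where it says the series, first, only, none or still open, it means among the compounds named here.

Compound 1 (`COC(=O)c1c(-c2cc(OC)cc(OC)c2)oc2ccccc2c1=O`) gives > 25 ug/mL (a limit)
Compound 2 (`COC(=O)c1c(-c2ccc(Br)cc2)oc2ccccc2c1=O`) gives > 25 ug/mL (a limit)
Compound 3 (`COC(=O)c1c(-c2ccc(O)cc2)oc2ccc(OC)cc2c1=O`) gives 18.7 ug/mL

In a functional assay on SK-MEL cells (Homo sapiens) for cytotoxicity, read by MTT assay, with a stated time of 6 days (a lower number here means that less compound is needed, a higher number that more compound is needed for the effect), compound 1 stands at > 25 ug/mL and this is a limit, not a number. Among the measured compounds the main feature is the limit of > 25 ug/mL in this assay, at which 2 of the 3 values shown sit, and only compound 3 gives a number. The move to compound 4 (`COc1cc(OC)cc(-c2oc3ccccc3c(=O)c2C(=O)O)c1`) is hydrogen in place of methyl on an oxygen next to a carbonyl group and puts hydrogen in place of methyl on an oxygen next to a carbonyl group. Among the compounds with values here, no measured pair shows this change. The expected step that the limit leaves unreadable from compound 1 to compound 4 in this assay is none beyond the scatter, in no set direction. That expectation rests on compound 1 with its limit of > 25 ug/mL alone. Compound 4 is estimated at 30 ug/mL with an expected range from 14 ug/mL to 70 ug/mL (most likely reported only as a limit).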

Compound 4, concentration for half-maximal effect: > 25 ug/mL
Compound 4 was reported as a limit; the forecaster's own chance of this, stated with the estimate: 75%; the middle value is on the limit's open side.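

No step can be read from compound 1 to compound 4, since both stand only as limits: the limit of > 25 ug/mL in this assay, at which 3 of the 4 values shown sit.

The compounds shown leave open whether methoxycarbonyl to carboxy on the shared core changes the value at all.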